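Swapping Methyl for Chloro on the Fused Ring

The source may hold more compounds than are shown below. What is called first, only, known or untested is meant among the compounds shown, and "the series" means these compounds.

Three compounds sharing a core of two fused rings with a pendant aromatic ring have been tested in an ADME assay on Vero cells (Chlorocebus sabaeus) for cytotoxicity, read by MTT assay, with a stated time of 72 h; on this read-out higher numbers stand for lower toxicity in this test and lower numbers for higher toxicity in this test. Compound 1, `Cc1cccc([C@@H]2C[C@H](O)Cc3ccccc3N2)c1`, gives > 300000 nM in this assay, which is a limit of the measurement and not a number, as recorded in the limit of > 300000 nM in this assay, at which 1 of the 3 values shown sits. Compound 2, `O[C@@H]1Cc2ccccc2N[C@H](c2cccc(Cl)c2)C1`, gives 295000 nM. Compound 3, `Cc1ccc2c(c1)C[C@@H](O)C[C@@H](c1ccccc1Cl)N2`, gives 82400 nM, the lowest of the two numbers, with compound 2 nearest, and the gap between them lies beyond the usual scatter.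

From compound 1 to compound 2 the change is chloro in place of methyl on an aromatic carbon, and in this assay it gave an at least 1.0-fold lower number from compound 1 to compound 2 (0.00 log units; that floor lies within the scatter). How the core of compound 3 differs from the core of compound 1 is not broken down here.

Compound 4, `O[C@@H]1Cc2cc(Cl)ccc2N[C@H](c2ccccc2Cl)C1`, is not yet measured. It differs from compound 3 by chloro in place of methyl on an aromatic carbon. This is the same kind of change as from compound 1 to compound 2, but the place differs: in compound 2 the chloro sits on a six-membered aromatic ring of carbon only, meta to a large group, whereas in compound 4 it sits on a ring that is part of a fused or bridged system of two rings, meta to a fused ring and para to a fused ring.

Compound 4 is expected to show a 1.2-fold lower number from compound 3 to compound 4 (0.07 log units; within the scatter) because an at least 1.0-fold lower number from compound 1 to compound 2 (0.00 log units; that floor lies within the scatter) stayed within the scatter. Compound 4 is therefore estimated at 70000 nM in this assay, most likely between 30000 nM and 170000 nM.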

Compound 4, half-maximal cytotoxic concentration: 106000 nM
For compound 4 the middle estimate is 1.5-fold (0.18 log units) below the measured one; the measured number falls inside the stated range.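

In this assay, chloro in place of methyl on an aromatic carbon of the fused system of two rings gave a 1.3-fold higher number from compound 3 to compound 4 (0.11 log units; within the scatter), which means that on this core the swap leaves the read-out within the usual scatter of repeated measurements. Set beside the earlier case, the comparison of the same change on the two cores reads: the same change on two cores in this assay, an at least 1.0-fold lower number (0.00 log units; that floor lies within the scatter) from compound 1 to compound 2 and a 1.3-fold higher number (0.11 log units; within the scatter) from compound 3 to compound 4; the limit leaves it open whether they differ This does not show that the swap carries over unchanged from one core to the other, because compound 1 stands at a limit of the assay and not at a number, which leaves only a floor for the earlier step: the limit of > 300000 nM in this assay, at which 1 of the 4 values shown sits.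

The compounds shown carry only methyl or chloro at the places compared, and how a different group, such as a methoxy group, an amine or a carboxylic acid, would read there in this assay remains open. Going by these compounds, the two steps also sit on different rings, and how the swap would read at one and the same place on both cores remains open too.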